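The source may report more compounds than this note shows. Statements on the series, on what has been measured and on what is new or still open speak of the compounds shown alone.

Measured compounds:
- compound 1 `CCc1cccc(NC(=O)CN2CCN(c3ccccn3)CC2)c1`: 28.7 nM
- compound 2 `Cc1cccc(NC(=O)CCN2CCN(c3ccccn3)CC2)c1`: 612 nM
- compound 3 `Cc1ccc(C2CCN(CC(=O)Nc3cccc(C)c3)CC2)nc1`: "not active" (no number reported)

In a functional assay on cells for agonist activity at D(4) dopamine receptor (Homo sapiens), read by TR-FRET and cAMP accumulation, with a stated time of 30 min (on this read-out higher numbers stand for an effect only at larger amounts of compound and lower numbers for an effect already at smaller amounts), compound 1 gives 28.7 nM, while compound 2 gives 612 nM. Compound 3 stands apart from both: in this assay compound 3 is recorded as "not active" (no number reported), so no number can be set beside it and no distance to compound 1 or compound 2 can be stated. Compound 1 and compound 2 share a pyridin-2-yl group on a ring nitrogen of their core, whereas compound 3 carries its aromatic group on a saturated ring carbon, and this arrangement is the only one among the measured set that yielded no measurable response.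

Compound 4 `Cc1ccc(C2CCN(CC(=O)Nc3cccc(C)c3)CC2)cc1` keeps the core and the amide side of compound 3 and changes only the aromatic group on the saturated carbon: 4-methylphenyl in place of 5-methylpyridin-2-yl on a saturated ring carbon. Going by the values given here, no step has been measured for this pair. From the compounds shown here alone, since compound 3 gave no number in this assay, the starting point is unknown, and the expectation for compound 4 can only be loose. Compound 4 is expected to remain weak in this assay, with an estimated half-maximal effective concentration of 3000 nM, in a range from 400 nM to 25000 nM, and a real chance that again only a limit is reported.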

Compound 4, half-maximal effective concentration: "not active" (no number reported)
For compound 4 the study gives words and no number, and the estimate cannot be compared.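

In this assay compound 3 is recorded as "not active" (no number reported) and compound 4 as "not active" (no number reported), so no step can be read between these two compounds. No evidence at hand bears on this result. The compounds shown leave open whether exchanging 5-methylpyridin-2-yl for 4-methylphenyl on the saturated ring carbon changes the response at all.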